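Methoxy to chloro on the 4-methoxybenzyl group

The compounds below may be only part of what the source reports. "The series", "measured", "known", "first", "only" and "open" are said of these compounds alone.

In a functional assay on HL-60 cells (Homo sapiens) for inhibition, read by CCK-8 assay, with a stated time of 48 h, tested at 20 uM (a lower number here means less inhibition of growth, a higher number more inhibition of growth at the concentration tested), compound 1 `COc1ccc(Cc2nnc(NC(=O)/C(C#N)=C/c3ccccc3OS(=O)(=O)c3ccc(OC)cc3)s2)cc1` gives 100%, the highest of three numbers, and the other two lie beyond the scatter from it. Compound 2 `COc1ccc(Cc2nnc(NC(=O)/C(C#N)=C/c3ccccc3OS(=O)(=O)c3ccc(Cl)cc3)s2)cc1` gives 20% and compound 3 `COc1ccc(Cc2nnc(NC(=O)/C(C#N)=C/c3ccccc3OS(=O)(=O)c3ccc(F)cc3)s2)cc1` gives 25%.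

Compound 4 `COc1ccc(S(=O)(=O)Oc2ccccc2/C=C(\C#N)C(=O)Nc2nnc(Cc3ccc(Cl)cc3)s2)cc1` carries chloro in place of methoxy on an aromatic carbon, turning 4-methoxybenzyl into 4-chlorobenzyl: chloro in place of methoxy on an aromatic carbon. The 4-methoxyphenyl group of compound 1 stays intact.

The closest evidence is the same exchange made on that other group, which gives a large step: a number 80 percentage points lower from compound 1 to compound 2 (beyond the scatter). Fluoro there gives a similarly large one: a number 75 percentage points lower from compound 1 to compound 3 (beyond the scatter). The halogens do not separate: a number 5 percentage points higher from compound 2 to compound 3 (within the scatter). Among the compounds with values here, no measured compound alters the benzyl group, so these steps carry over only loosely.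

A substantial fall is expected, probably smaller than those two, with wide uncertainty. The expected change is a number 50 percentage points lower from compound 1 to compound 4 (beyond the scatter). For compound 4 the estimate is 50%, with an expected range from 15% to 95%.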

Compound 4, percent growth inhibition at one concentration: 99%
For compound 4 the middle estimate is 49 percentage points below the measured one; measured number outside the range, above it.
By their numbers in this assay, from the lowest: compounds 2 and 3 (each within the scatter of the next); then compounds 4 and 1 (each within the scatter of the next).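

In this assay the exchange on the 4-methoxybenzyl group gives a number 1 percentage points lower from compound 1 to compound 4 (within the scatter) and shows that this position tolerates chloro in place of methoxy at the concentration tested. Within the data shown here, the same exchange on the 4-methoxyphenyl group gives a number 80 percentage points lower from compound 1 to compound 2 (beyond the scatter) and so the outcome of this change depends on which of the two groups carries it, a dependence the earlier compounds could not show. Nothing at hand explains why the two groups part in this way.

Still open, on these data alone, is how far this tolerance extends: fluoro on the benzyl group, or an amine, a carboxylic acid or a longer chain at the same place, would test it. A reading at one concentration also leaves open whether compound 1 and compound 4 would separate at lower concentrations.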